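A few compounds are considered here, and "the series" means these few. Any claim that something is new, unique, unknown or untested is made for them only; others in the source may bear on it.

Compound 1 `COc1cc(C(C)=O)ccc1OCCCCN1CCC(C(c2ccc(F)cc2)c2ccc(F)cc2)CC1`: 2.51 nM
Compound 2 `CCc1ccc(OCCCN2CCC(C(c3ccc(F)cc3)c3ccc(F)cc3)CC2)c(OC)c1`: 2.51 nM

In a functional assay (aorta) with Oryctolagus cuniculus as the target (a lower number here means tighter binding, a higher number weaker binding), compound 2 gives 2.51 nM, level at the digits shown with compound 1, which gives 2.51 nM; the two lie within the usual scatter, so neither stands apart. Compound 3 `Fc1ccc(C(c2ccc(F)cc2)C2CCN(CCCOc3ccccc3)CC2)cc1` has not yet been measured in this assay. It differs from compound 2 in one place: phenyl in place of 4-ethyl-2-methoxyphenyl on an oxygen on a saturated carbon. The two measured compounds offer no comparison of such a change, so the expectation rests only on how much of the group is removed. The change is expected to weaken binding by a modest step, a 3.2-fold higher number from compound 2 to compound 3 (0.50 log units; beyond the scatter), probably just beyond the scatter. Compound 3 is therefore estimated at 8 nM, with a range from 2.5 nM to 25 nM.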

Compound 3, dissociation constant: 1.59 nM
Compound 3: middle estimate off by 5.0-fold (0.70 log units), on the high side; the measured number lies below the stated range.
By their numbers in this assay, from the lowest: compounds 3, 1 and 2 (each within the scatter of the next).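

In this assay, putting phenyl in place of 4-ethyl-2-methoxyphenyl on the oxygen gives a 1.6-fold lower number from compound 2 to compound 3 (0.20 log units; within the scatter) and so leaves binding unchanged within the usual scatter. The ethyl and methoxy groups can therefore both go at once, and the bare phenyl still binds as tightly as the larger group does. No measurement shown gives a reason for this result. As far as these compounds go, because both groups leave together, what each contributes alone stays open. So does whether a ring carrying an amine or a carboxylic acid would bind as well.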